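The source may hold more compounds than are shown below. What is called first, only, known or untested is meant among the compounds shown, and "the series" means these compounds.

In a functional assay on MCF7 cells (Homo sapiens) for antiproliferative activity, read by MTT assay, with a stated time of 72 h (a lower number here means a stronger inhibitor, a higher number a weaker inhibitor), compound 2, `COc1cc(CC(COCc2ccccc2)COCc2ccccc2)nc(OC)n1`, gives 300 nM. For the measured compounds named here, that is the only actual number measured in this assay among the compounds here; the other value recorded is a limit rather than a number. Compound 1, `O=c1cc(CC(O)(COCc2ccccc2)COCc2ccccc2)[nH]c(=O)[nH]1`, gives > 100000 nM in this assay, and this is a limit of the assay, not a measured number. Compound 3, `O=c1cc(CC(COCc2ccccc2)COCc2ccccc2)[nH]c(=O)[nH]1`, has not yet been measured. It differs from compound 2 in a single way: a group of 8 heavy atoms (4 carbon, 2 nitrogen, 2 oxygen; one six-membered aromatic ring with 2 hetero atoms) in place of a group of 10 heavy atoms (6 carbon, 2 nitrogen, 2 oxygen; one six-membered aromatic ring with 2 hetero atoms), on a saturated chain carbon, three bonds along the chain from two oxygens on a saturated carbon. Going by the values given here, no step between two measured compounds covers exactly this change, so its size has to be judged from the surrounding data. Compound 1 also carries a group of the kind that enters here, and its result in this assay is only (the limit of > 100000 nM in this assay, at which 1 of the 2 values shown sits). On that basis compound 3 is expected to be a much weaker inhibitor than compound 2, a step estimated at a 100-fold higher number from compound 2 to compound 3 (2.00 log units; beyond the scatter) in this assay. The estimate for compound 3 in this assay is 30000 nM, with a range from 3000 nM to 100000 nM, and there is a fair chance that this assay again reports only a limit.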

Compound 3, half-maximal inhibitory concentration: > 100000 nM
Compound 3 gave a limit, no number; the forecaster's own chance of this, stated with the estimate: 50%; middle value at least 3.3-fold (0.52 log units) away from the limit.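

In this assay, replacing the 2,6-dimethoxypyrimidin-4-yl group on this saturated chain carbon gives an at least 330-fold higher number from compound 2 to compound 3 (2.52 log units; beyond the scatter), and that size is only a floor, since the value for compound 3 is a limit of the assay. Compound 1 carries the same entering group but also a hydroxy, so it could not show whether the ring change alone was enough to lose the activity; compound 3 has hydrogen in place of that hydroxy and shows that the ring change alone is enough. The step between compound 1 and compound 3 cannot be read, so any effect of the hydroxy stays hidden, and the two compounds with the entering group do not separate: the limit of > 100000 nM in this assay, at which 2 of the 3 values shown sit.

For the compounds shown here, with compound 2 as the only compound giving an actual number, the data do not show which part of the 2,6-dimethoxypyrimidin-4-yl group matters, or whether the two methoxy groups could be replaced by ethoxy groups or amines and keep the activity. They also leave open what a hydroxy on the saturated chain carbon would do to the number of compound 2, where a change could be measured rather than hidden at a limit.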